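The compounds below may be only part of what the source reports. "The series", "measured", "known", "first", "only" and "open" are said of these compounds alone.

Going by the values given here, compound 3 `CCO/N=C(\CCN1CCN(c2cccc(OCC)c2)CC1)c1ccccc1` stands at the top of the three numbers so far in a functional assay on HEK293 cells with D(4) dopamine receptor (Homo sapiens) as the target, read by FLIPR (a lower number here means a smaller maximal response, a higher number a larger maximal response), giving 84%, with compound 1 `CCO/N=C(\CCN1CCN(c2ccccc2C#N)CC1)c1ccccc1` within the scatter of it at 82%; compound 2 `CCO/N=C(\CCN1CCN(c2cccc(OC)c2)CC1)c1ccccc1` gives 30% and sits well below both. The two steps that replace the group on the ring nitrogen, a number 52 percentage points lower from compound 1 to compound 2 (beyond the scatter) and a number 2 percentage points higher from compound 1 to compound 3 (within the scatter), show that such a swap can leave the read-out unchanged or cut it sharply, and the step of a number 54 percentage points higher from compound 2 to compound 3 (beyond the scatter) shows how much this position can swing on a small change. Compound 4 `CCO/N=C(\CCN1CCN(c2ncccc2C)CC1)c1ccccc1` brings the change (3-methylpyridin-2-yl in place of 3-ethoxyphenyl on an amine nitrogen in a ring). Those three steps bear on it, but none of them introduces a ring with a hetero atom at this position, so the direction is open and a step of either size is possible. On balance, for compound 4 a step of a number 24 percentage points lower from compound 3 to compound 4 (beyond the scatter) is expected. The estimate for compound 4 in this assay is 60%, within 25% to 90%.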

Compound 4, largest response reached (reported as efficacy), in percent of the reference or control that the assay uses: 49%
Beside the measured number, compound 4's estimate is 11 percentage points above it; low and high end bracket the measured number.
By their numbers in this assay, from the lowest: compound 2; then compound 4; then compounds 1 and 3 (each within the scatter of the next).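

In this assay, going by these compounds alone, 3-methylpyridin-2-yl, the only group here with a hetero atom in its aromatic ring, gives an intermediate result on the amine nitrogen in a ring: a number 35 percentage points lower from compound 3 to compound 4 (beyond the scatter) and a number 33 percentage points lower from compound 1 to compound 4 (beyond the scatter), while a number 19 percentage points higher from compound 2 to compound 4 (beyond the scatter). The position is therefore not restricted to the high level of compounds 1 and 3 and the low level of compound 2. The step from compound 3 changes the ring and removes the ethoxy group together, so their separate contributions cannot be read.

On these data alone, whether a pyridin-2-yl group carrying ethoxy in place of methyl would stand nearer compound 3 or compound 4 remains open. No measurement shown accounts for any of these steps.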